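A few compounds are considered here, and "the series" means these few. Any claim that something is new, unique, unknown or untested is made for them only; others in the source may bear on it.

In an ADME assay on HepG2 cells (Homo sapiens) for cytotoxicity, read by luminescence, CellTiter-Glo and ATP content, with a stated time of 72 h (on this read-out lower numbers stand for an effect already at smaller amounts and higher numbers for an effect only at larger amounts of compound), three compounds have been measured so far. Compound 1 `COc1ccc(Oc2ccc3c(NCCCNCc4cc(F)ccc4OC)ccnc3c2)cc1` gives 7000 nM, compound 2 `COc1cccc(CNCCCNc2ccnc3cc(Cc4cccc(C(F)(F)F)c4)ccc23)c1O` gives 1720 nM, and compound 3 `COc1ccc(F)cc1CNCCCNc1ccnc2cc(CC3CCCCC3)ccc12` gives 1830 nM. Among the measured compounds shown here, compound 3 thus holds the second highest of the three numbers: compound 2 sits within the scatter of it, while compound 1 is set apart by the only measured step, a 3.8-fold lower number from compound 1 to compound 3 (0.58 log units; beyond the scatter).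

Compound 4 `COc1ccc(F)cc1CNCCCNc1ccnc2cc(Cc3cccc(C(F)(F)F)c3)ccc12` differs from compound 3 in one place: 3-(trifluoromethyl)phenyl in place of cyclohexyl on a saturated chain carbon bound to an aromatic carbon. For the measured compounds named here, no measured step covers this exact change. Going by the values given here, the one step on record, a 3.8-fold lower number from compound 1 to compound 3 (0.58 log units; beyond the scatter), concerns a different swap and so says little here. What does bear on it is compound 2, which carries the same 3-(trifluoromethyl)benzyl group as compound 4 and differs from it elsewhere in the structure; compound 2 gives 1720 nM, within the scatter of compound 3. That suggests the group entering in compound 4 is tolerated without a visible shift. On that basis the step is expected to stay within the scatter: a 1.1-fold lower number from compound 3 to compound 4 (0.03 log units; within the scatter). Compound 4 is therefore estimated at 1700 nM, with a likely range from 700 nM to 4000 nM.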

Compound 4, half-maximal effective concentration: 440 nM
Estimate against measurement, compound 4: 3.9-fold (0.59 log units) above; measured number outside the range, below it.
By their numbers in this assay, from the lowest: compound 4; then compounds 2 and 3 (each within the scatter of the next); then compound 1.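

Placed on a saturated chain carbon bound to an aromatic carbon, 3-(trifluoromethyl)phenyl in place of cyclohexyl gives a 4.2-fold lower number from compound 3 to compound 4 (0.62 log units; beyond the scatter), so cytotoxicity appears at smaller amounts and this position clearly responds to the group it carries. The 3-(trifluoromethyl)benzyl group does not set the number alone: 5-fluoro-2-methoxyphenyl in place of 2-hydroxy-3-methoxyphenyl on a saturated chain carbon bound to an amine nitrogen gives a 3.9-fold lower number from compound 2 to compound 4 (0.59 log units; beyond the scatter), while 3-(trifluoromethyl)benzyl in place of 4-methoxyphenoxy on an aromatic carbon gives the widest step here, a 16-fold lower number from compound 1 to compound 4 (1.20 log units; beyond the scatter). No measurement available here explains why these changes shift the number.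

The compounds shown cannot separate the contribution of the aromatic ring from that of the trifluoromethyl group, and a plain phenyl on the same chain carbon would be the direct comparison with both compound 3 and compound 4. As far as these compounds go, it also remains open how the number would respond if the trifluoromethyl group gave way to a carboxylic acid or an amine on that ring.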